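Dropping the chloro of compound 1: expected effect

A few compounds are considered here, and "the series" means these few. Any claim that something is new, unique, unknown or untested is made for them only; others in the source may bear on it.

Compound 1 `COc1cc(Cl)cc(-c2nn(-c3cccc(NC(=O)Nc4ccc(Cl)c(C(F)(F)F)c4)c3)cc2-c2ccncc2)c1` is the lower of the two measured numbers in a functional assay on SNB-75 cells (Homo sapiens) for inhibition, read by sulforhodamine B assay, with a stated time of 48 h, tested at 0.01 uM; on this read-out higher numbers stand for a weaker effect at the one concentration tested and lower numbers for a stronger effect; compound 1 gives 57%. Compound 2 `COc1cc(Cl)cc(-c2nn(-c3cccc(NC(=O)Nc4cc(C(F)(F)F)cc(C(F)(F)F)c4)c3)cc2-c2ccncc2)c1` sits higher in this assay, and compound 2 gives 71%, a gap beyond the usual scatter. Compound 3 `COc1cc(Cl)cc(-c2nn(-c3cccc(NC(=O)Nc4cccc(C(F)(F)F)c4)c3)cc2-c2ccncc2)c1` has not been measured. The change from compound 1 to compound 3 is hydrogen in place of chloro on an aromatic carbon. Among the measured compounds shown here, no step of this kind is known from the measured pair; a modest move toward a weaker effect is expected, a number 11 percentage points higher from compound 1 to compound 3 (beyond the scatter), since the only other variation of this aryl group, compound 2 at 71%, also reads higher. Compound 3 is estimated at 68%, in the range 52% to 85%.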

Compound 3, a percentage reported as activity, at one concentration (the size of the read-out at that concentration, not a potency): 83%
Compound 3: middle estimate off by 15 percentage points, on the low side; the range from low to high includes it.
By their numbers in this assay, from the lowest: compound 1; then compound 2; then compound 3.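

Going from 4-chloro-3-(trifluoromethyl)phenyl to 3-(trifluoromethyl)phenyl in this assay gives a number 26 percentage points higher from compound 1 to compound 3 (beyond the scatter) and shows that the chloro counts toward the stronger effect at this position. Hydrogen in place of trifluoromethyl points the same way, with a number 12 percentage points higher from compound 2 to compound 3 (beyond the scatter) marking a second loss of effect, so compound 3, with neither extra group, reads highest of the three. No evidence bearing on the origin of these steps is available. From the compounds shown here alone, whether a fluoro, a methyl or a methoxy at the chloro position would keep the effect stays open, as does whether the trend holds at other concentrations.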